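The compounds below may be only part of what the source reports. "The series", "measured", "known", "first", "only" and "open" are said of these compounds alone.

In a functional assay on the whole organism for inhibition, with Mus musculus as the target (a higher number here means that more compound is needed for the effect, a lower number that less compound is needed), three compounds have been measured:
compound 1 `CCN1CCCC1CNC(=O)c1cc(NS(=O)(=O)N(C)C)c(C)cc1OC` gives 13.3 mg/kg;
compound 2 `CCN1CCCC1CNC(=O)c1cc(NS(=O)(=O)N(C)C)c(Cl)cc1OC` gives 8.3 mg/kg;
compound 3 `CCN1CCCC1CNC(=O)c1cc(NS(N)(=O)=O)c(C)cc1OC` reaches only a limit of the assay, > 50 mg/kg.

Compound 4 `CCN1CCCC1CNC(=O)c1cc(NS(N)(=O)=O)c(Cl)cc1OC` has not yet been measured in this assay. It differs from compound 3 by chloro in place of methyl on an aromatic carbon. The same kind of change joins compound 1 to compound 2, (chloro in place of methyl on an aromatic carbon), though the surroundings differ: there the place is "ortho to a (dimethylsulfamoyl)amino group", here it is "ortho to a sulfamoylamino group". That measured step was a 1.6-fold lower number from compound 1 to compound 2 (0.20 log units; within the scatter). The two cores differ by amino in place of dimethylamino on a sulfonyl sulfur, a step of an at least 3.7-fold higher number from compound 1 to compound 3 (0.57 log units; beyond the scatter). Compound 3 stands at the limit of > 50 mg/kg in this assay, at which 1 of the 3 values shown sits, so its value is known only as a floor. Because the step of a 1.6-fold lower number from compound 1 to compound 2 (0.20 log units; within the scatter) lay within the scatter, compound 4 is expected to move by about a step that the limit leaves unreadable from compound 3 to compound 4, most likely remaining at the limit. Compound 4 is therefore estimated at 60 mg/kg, between 25 mg/kg and 200 mg/kg.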

Compound 4, dose for half-maximal effect: > 50 mg/kg
Compound 4 ended at the assay's limit; the forecaster's own chance of this, stated with the estimate: 70%; the middle value does not contradict the limit.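

In this assay compound 4 stands at > 50 mg/kg, which is a limit of the assay, so the step of chloro in place of methyl from compound 3 cannot be read. Amino in place of dimethylamino on the sulfonyl sulfur gives an at least 6.0-fold higher number from compound 2 to compound 4 (0.77 log units; beyond the scatter), and the change points the same way on both cores: the same change on two cores in this assay, an at least 3.7-fold higher number (0.57 log units; beyond the scatter) from compound 1 to compound 3 and an at least 6.0-fold higher number (0.77 log units; beyond the scatter) from compound 2 to compound 4; the limit leaves it open whether they differ. This shows that the direction of the change carries over between these two cores, but it does not show that its size is the same.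

The compounds shown leave open whether a single methylamino or a diethylamino group on the sulfonyl sulfur would keep the number below the limit. They also leave open how chloro and methyl compare when amino sits on that sulfur.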